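Replacing dimethylsulfamoyl with methylsulfonyl

A few compounds are considered here, and "the series" means these few. Any claim that something is new, unique, unknown or untested is made for them only; others in the source may bear on it.

Values in a physicochemical assay for solubility, read by HPLC, in phosphate buffer, measured as kinetic solubility, at pH 7.4; a lower number here means a less soluble compound, a higher number a more soluble compound:
- compound 1 `CCC(=O)c1cc(-c2ccc(Cl)cc2)n(-c2ccc(S(=O)(=O)NC)cc2)c1C`: 8700 nM
- compound 2 `CCC(=O)c1cc(-c2ccc(Cl)cc2)n(-c2ccc(S(=O)(=O)N(C)C)cc2)c1C`: 1200 nM

Compound 2, at 1200 nM, holds the lower of the two numbers, and the gap lies beyond the scatter. Next comes compound 3 `CCC(=O)c1cc(-c2ccc(Cl)cc2)n(-c2ccc(S(C)(=O)=O)cc2)c1C`, with methyl in place of dimethylamino on a sulfonyl sulfur. Going by the values given here, no measured step covers this exact change. One bears on it loosely: a 7.3-fold lower number from compound 1 to compound 2 (0.86 log units; beyond the scatter), with methyl in place of hydrogen on a sulfonamide nitrogen. Going by that step alone, a modest rise in this assay is expected for compound 3, where dimethylamino leaves. The expected change is a 2.1-fold higher number from compound 2 to compound 3 (0.32 log units; beyond the scatter). For compound 3 the estimate is 2500 nM, with an expected range of 800 nM to 8000 nM.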

Compound 3, solubility: 4800 nM
Estimate against measurement, compound 3: 1.9-fold (0.28 log units) below; low and high end bracket the measured number.
By their numbers in this assay, from the lowest: compound 2; then compounds 3 and 1 (each within the scatter of the next).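

In this assay, methyl in place of dimethylamino on the sulfonyl sulfur (a 4.0-fold higher number from compound 2 to compound 3 (0.60 log units; beyond the scatter)) shows that the low reading of compound 2 does not carry over to compound 3. Methyl in place of methylamino (a 1.8-fold lower number from compound 1 to compound 3 (0.26 log units; within the scatter)) separates compound 1 and compound 3 by no more than the usual scatter, so among these three sulfonyl substituents only dimethylamino stands apart. No evidence at hand accounts for this.

Still open, as far as these compounds go, is whether an unsubstituted amino group or a cyclic amine such as morpholine on the sulfonyl sulfur would read with compound 2 or with compound 3.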